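The compounds below may be only part of what the source reports. "The series", "measured", "known", "first", "only" and "open" are said of these compounds alone.

Measured in a functional assay on K562 cells (Homo sapiens) for inhibition, read by trypan blue exclusion, with a stated time of 72 h; on this read-out higher numbers stand for weaker inhibition and lower numbers for stronger inhibition:
compound 1 `Cn1c(=O)c(S(=O)(=O)c2ccc(Cl)cc2Cl)cc2cnc(Nc3ccc4[nH]ccc4c3)nc21`: 1000 nM
compound 2 `Cn1c(=O)c(S(=O)(=O)c2ccc(F)cc2)cc2cnc(Nc3ccc4cc[nH]c4c3)nc21`: 10000 nM
compound 3 `COc1ccc(S(=O)(=O)c2cc3cnc(Nc4ccc5[nH]ccc5c4)nc3n(C)c2=O)cc1`: 300 nM

Of these three, compound 3 holds the lowest number in this assay (300 nM). Compound 1 is its nearest neighbour and compound 2 its furthest.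

Next is compound 4 `Cn1c(=O)c(S(=O)(=O)c2ccc(F)cc2)cc2cnc(Nc3ccc4[nH]ccc4c3)nc21`, which differs from compound 3 by fluoro in place of methoxy on an aromatic carbon. This is fluoro in place of methoxy on an aromatic carbon, para to a large group, so 4-methoxyphenyl becomes 4-fluorophenyl.

Among the measured compounds shown here, only one measured step changes this aryl group: a 3.3-fold lower number from compound 1 to compound 3 (0.52 log units; beyond the scatter). For the measured compounds named here, it starts from a different group, so no measured pair compares fluoro with methoxy directly. Compound 2 also carries 4-fluorophenyl but differs from compound 4 elsewhere in the molecule. Going by the values given here, no step links the two, so its number is not carried over.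

Leaving the 4-methoxyphenyl of compound 3 is expected to give a modest move to a higher number, of about the size of the one measured step. The expected change is a 2.3-fold higher number from compound 3 to compound 4 (0.37 log units; beyond the scatter) and remains an estimate. For compound 4 the estimated value is 700 nM with an expected range from 200 nM to 2500 nM in this read-out.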

Compound 4, half-maximal inhibitory concentration: 200 nM
For compound 4 the middle estimate is 3.5-fold (0.54 log units) above the measured one, and the stated range covers the measured number.
By their numbers in this assay, from the lowest: compounds 4 and 3 (each within the scatter of the next); then compound 1; then compound 2.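

In this assay, among the compounds shown here, the first direct comparison of the two groups on the aromatic carbon, para to a large group, gives a 1.5-fold lower number from compound 3 to compound 4 (0.18 log units; within the scatter) and so does not separate fluoro from methoxy. For the compounds shown here, replacing 2,4-dichlorophenyl on the sulfonyl sulfur with 4-fluorophenyl gives a 5.0-fold lower number from compound 1 to compound 4 (0.70 log units; beyond the scatter) and adds a second modest step in the same direction as the one to the 4-methoxyphenyl compound, while moving from 1H-indol-6-yl to 1H-indol-5-yl with 4-fluorophenyl held constant gives a 50-fold lower number from compound 2 to compound 4 (1.70 log units; beyond the scatter) and is the largest single-place step, which makes the attachment point of the indole the more sensitive of the two sites on this evidence. Nothing in the data accounts for the size of any of these steps.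

The compounds shown leave open whether a hydroxyl, an amine or a carboxylic acid in the same place on the phenyl ring would stay level with compound 3 and compound 4. Also open, from the compounds shown here alone, is whether the gap between 1H-indol-5-yl and 1H-indol-6-yl holds with 4-methoxyphenyl on the sulfonyl sulfur, as 1H-indol-6-yl appears here only in compound 2.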